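This account rests on a few compounds, and the source may have more. Where it says the series, first, only, none or still open, it means among the compounds named here.

In a functional assay on RS4-11 cells (Homo sapiens) for inhibition, read by CCK-8 assay, with a stated time of 72 h (on this read-out higher numbers stand for weaker inhibition and lower numbers for stronger inhibition), compound 1 `CC1(C)CCC(CN2CCN(c3ccc(C(=O)NS(=O)(=O)c4ccc(NCC5CCOCC5)c([N+](=O)[O-])c4)c(Oc4cnc5[nH]ccc5c4)c3)CC2)=C(c2ccc(Cl)cc2C(F)(F)F)C1` gives 74 nM, compound 2 `COc1ccc(C2=C(CN3CCN(c4ccc(C(=O)NS(=O)(=O)c5ccc(NCC6CCOCC6)c([N+](=O)[O-])c5)c(Oc5cnc6[nH]ccc6c5)c4)CC3)CCC(C)(C)C2)cc1` gives 12 nM and compound 3 `CN1CCC(CNc2ccc(S(=O)(=O)NC(=O)c3ccc(N4CCN(CC5=C(c6ccc(C(F)(F)F)cc6)CC(C)(C)CC5)CC4)cc3Oc3cnc4[nH]ccc4c3)cc2[N+](=O)[O-])C1` gives 8.3 nM. Going by the values given here, compound 3 therefore has the lowest of the three numbers, but its value lies within the scatter of the one for compound 2. The value for compound 1 stands clearly apart from it, beyond the scatter.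

Compound 4 `CC1(C)CCC(CN2CCN(c3ccc(C(=O)NS(=O)(=O)c4ccc(NC5CCOC5)c([N+](=O)[O-])c4)c(Oc4cnc5[nH]ccc5c4)c3)CC2)=C(c2ccc(C(F)(F)F)cc2)C1` departs from compound 3 in one place: oxolan-3-yl in place of (1-methylpyrrolidin-3-yl)methyl on a nitrogen on an aromatic ring. Among the compounds with values here, the single measured step, a 6.2-fold lower number from compound 1 to compound 2 (0.79 log units; beyond the scatter), replaces 4-chloro-2-(trifluoromethyl)phenyl with 4-methoxyphenyl on a double-bonded ring carbon. That is a different place, so its size cannot be carried over to the new change. Within the data shown here, no measured step isolates the group on the nitrogen. There is only indirect evidence: compound 2 carries a different group there from compound 3, and also a different group on the double-bonded ring carbon, yet compound 2 at 12 nM stays within the scatter of compound 3.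

In this assay, no step beyond the scatter is therefore expected, though a slightly higher number seems more likely than a lower one. The estimated change is a 1.7-fold higher number from compound 3 to compound 4 (0.23 log units; within the scatter). The expected value for compound 4 is 14 nM, with an estimated range of 4 nM to 45 nM.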

Compound 4, half-maximal inhibitory concentration: 32 nM
Compound 4: the middle estimate sits 2.3-fold (0.36 log units) below what was measured, and the stated range covers the measured number.
By their numbers in this assay, from the lowest: compounds 3 and 2 (each within the scatter of the next); then compound 4; then compound 1.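

Going by these compounds alone, the change from (1-methylpyrrolidin-3-yl)methyl to oxolan-3-yl on the nitrogen on an aromatic ring gives a 3.9-fold higher number from compound 3 to compound 4 (0.59 log units; beyond the scatter), the first step in this assay that isolates this position and shows that the group there can move the read-out beyond the scatter. The size of the step is set against a small structural difference: the entering group has 5 heavy atoms against 7, oxygen takes the place of nitrogen as the ring hetero atom, and both groups share a five-membered non-aromatic ring, the same counts of hydrogen-bond donors and acceptors, and no net charge. Nothing available explains why the number rises, so the step stands as an observation without a measured cause.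

The compounds shown leave open which part of the change carries the step, the ring hetero atom or the remaining differences in the group, as these are bundled together in this single pair. A (oxolan-3-yl)methyl or a 1-methylpyrrolidin-3-yl group on the same nitrogen, with the rest of compound 3 kept, would separate them.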